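From Acetoxy to Propanoyloxy on Compound 3

A few compounds are considered here, and "the series" means these few. Any claim that something is new, unique, unknown or untested is made for them only; others in the source may bear on it.

In a functional assay on the whole organism with Mus musculus as the target, in the maximal electroshock model (a higher number here means that more compound is needed for the effect, a lower number that less compound is needed), compound 1 `Clc1ccccc1-c1ccc(N2CCC3(CC2)OCCO3)nn1` gives 57 mg/kg, compound 2 `O=COC1CCN(c2ccc(-c3ccc(Cl)cc3Cl)nn2)CC1` gives 24 mg/kg and compound 3 `CC(=O)OC1CCN(c2ccc(-c3ccc(Cl)cc3Cl)nn2)CC1` gives 14 mg/kg. Compound 3 thus stands within the scatter of compound 2, and its number lies well under that of compound 1. Compound 4 `CCC(=O)OC1CCN(c2ccc(-c3ccc(Cl)cc3Cl)nn2)CC1` differs from compound 3 by methyl in place of hydrogen on a saturated chain carbon bound to a carbonyl carbon, which turns acetoxy into propanoyloxy. Going by the values given here, the one measured step that bears on this is the related methyl addition on the carbonyl carbon, a 1.7-fold lower number from compound 2 to compound 3 (0.23 log units; within the scatter). That step gives no ground to expect a shift beyond the scatter in this assay. The expected step is a 1.1-fold lower number from compound 3 to compound 4 (0.03 log units; within the scatter). The estimated value for compound 4 is 13 mg/kg, within a range of 6 mg/kg to 28 mg/kg.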

Compound 4, dose for half-maximal effect: 50 mg/kg
The estimate for compound 4 lay 3.8-fold (0.59 log units) below the measured number, outside the stated range (above it).
By their numbers in this assay, from the lowest: compounds 3 and 2 (each within the scatter of the next); then compounds 4 and 1 (each within the scatter of the next).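

In this assay the length of the ester chain matters at this position: acetoxy to propanoyloxy gives a 3.6-fold higher number from compound 3 to compound 4 (0.55 log units; beyond the scatter) and so costs more than the scatter. Counted over both added carbons, the change gives a 2.1-fold higher number from compound 2 to compound 4 (0.32 log units; beyond the scatter) as well, whereas the methyl step on the carbonyl carbon stayed within the scatter, so a shift beyond the scatter appears only with the second added carbon. Nothing at hand accounts for this shift. On these data alone, whether a longer chain such as butanoyloxy would raise the number further remains open. So does whether an amide in place of the ester would behave the same way.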